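From 3-methoxyphenyl to 2-chlorophenyl on a shared core

This account rests on a few compounds, and the source may have more. Where it says the series, first, only, none or still open, it means among the compounds named here.

Compound 1 `CN1CCC(COC(c2ccccc2)c2ccccc2)CC1` gives > 20000 nM (a limit of the assay)
Compound 2 `Cc1ccc(CCCN2CCC(COC(c3ccccc3)c3ccccc3)CC2)cc1` gives 200 nM
Compound 3 `COc1cccc(CCCN2CCC(COC(c3ccccc3)c3ccccc3)CC2)c1` gives 1500 nM

These results come from a functional assay on cells (T-cell line, Homo sapiens) for inhibition (a lower number here means a stronger inhibitor, a higher number a weaker inhibitor), and are the only data available. Compound 1 reaches only a limit (> 20000 nM). Of the two actual numbers, compound 3 (1500 nM) has the higher, and compound 2 (200 nM) the lower.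

The change under consideration gives compound 4 (`Clc1ccccc1CCCN1CCC(COC(c2ccccc2)c2ccccc2)CC1`), with 2-chlorophenyl in place of 3-methoxyphenyl on a saturated chain carbon, three bonds along the chain from an amine nitrogen in a ring. Two large steps show what the whole substituted chain brings (an at least 100-fold lower number from compound 1 to compound 2 (2.00 log units; beyond the scatter)) (an at least 13-fold lower number from compound 1 to compound 3 (1.12 log units; beyond the scatter)), and compound 4 keeps such a chain, as 2-(2-chlorophenyl)ethyl. For the measured compounds named here, the closest precedent is the only exchange of one substituted phenyl for another, which is modest (a 7.5-fold higher number from compound 2 to compound 3 (0.88 log units; beyond the scatter)). Going by the values given here, no chlorinated compound has been measured, so a modest step is expected, toward a lower number, leaving compound 4 near the span set by compound 2 and compound 3. The expected move is (a 2.5-fold lower number from compound 3 to compound 4 (0.40 log units; beyond the scatter)). Compound 4 is estimated at 600 nM in this assay with an expected range (130 nM to 2800 nM).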

Compound 4, half-maximal inhibitory concentration: 800 nM
Estimate against measurement, compound 4: 1.3-fold (0.12 log units) below; low and high end bracket the measured number.
By their numbers in this assay, from the lowest: compound 2; then compounds 4 and 3 (each within the scatter of the next). At a limit, above all of these: compound 1.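

In this assay, the exchange of 3-methoxyphenyl for 2-chlorophenyl on the saturated chain carbon stays within the scatter (a 1.9-fold lower number from compound 3 to compound 4 (0.27 log units; within the scatter)), so this position tolerates the loss of the methoxy oxygen and the arrival of chlorine without a change that can be read. Compound 2 now stands apart from two differently substituted rings rather than one (a 4.0-fold higher number from compound 2 to compound 4 (0.60 log units; beyond the scatter)), and of the three substituted phenyl groups shown, 4-methylphenyl alone gives a number beyond the scatter of the others. A third substituted chain repeats the large step from the core of compound 1 (an at least 25-fold lower number from compound 1 to compound 4 (1.39 log units; beyond the scatter)), a step that is read from a limit and not from a number: (the limit of > 20000 nM in this assay, at which 1 of the 4 values shown sits).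

The exchange alters both the substituent and where it sits on the ring, so the compounds shown cannot separate the two, and 4-chlorophenyl, 3-chlorophenyl or 4-methoxyphenyl would be needed to do so. They also leave open whether the 4-methylphenyl result extends to a larger group such as 4-ethylphenyl, and how a longer chain to the ring would behave.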